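Adding a fluoro to the second phenyl of compound 2

The compounds below may be only part of what the source reports. "The series", "measured", "known", "first", "only" and "open" are said of these compounds alone.

Compound 1, `Cc1ccc(-c2nn(-c3ccccc3)cc2C(=O)NC(=S)Nc2ccc(Cl)cc2)cc1`, gives 6210 nM in a functional assay on MCF7 cells (Homo sapiens) for inhibition, read by CCK-8 assay, with a stated time of 48 h; a higher number here means a weaker inhibitor, a lower number a stronger inhibitor.
Compound 2, `O=C(NC(=S)Nc1ccc(F)cc1)c1cn(-c2ccccc2)nc1-c1ccccc1`, gives 6820 nM.
Compound 3, `Cc1ccc(NC(=S)NC(=O)c2cn(-c3ccccc3)nc2-c2ccccc2)cc1`, gives 5900 nM.

The three numbers sit close together. Going by the values given here, compound 2 gives the highest of them, but no other compound is separated from it by more than the scatter: compound 1 is nearest, and the step of a 1.2-fold lower number from compound 2 to compound 3 (0.06 log units; within the scatter) is within the scatter as well.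

Compound 4, `O=C(NC(=S)Nc1ccc(F)cc1)c1cn(-c2ccccc2)nc1-c1ccc(F)cc1`, is compound 2 with fluoro in place of hydrogen on an aromatic carbon. Among the compounds with values here, no measured step bears directly on this change. Within the data shown here, the only step that is known, a 1.2-fold lower number from compound 2 to compound 3 (0.06 log units; within the scatter), alters the other aryl ring, and it is within the scatter. Compound 1 carries a methyl on the ring in question together with a chloro on the other ring, so it differs from compound 2 in two places; the value of compound 1, 6210 nM, lies within the scatter of the value of compound 2. With nothing pointing either way, the step from compound 2 to compound 4 in this assay is expected to stay within the scatter, a 1.0-fold lower number from compound 2 to compound 4 (0.02 log units; within the scatter). Compound 4 is therefore estimated at 6500 nM, with a range from 3000 nM to 14000 nM.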

Compound 4, half-maximal inhibitory concentration: 5610 nM
Estimate against measurement, compound 4: 1.2-fold (0.06 log units) above, and the stated range covers the measured number.
By their numbers in this assay, from the lowest: compounds 4, 3, 1 and 2 (each within the scatter of the next).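

In this assay, going by these compounds alone, the change from phenyl to 4-fluorophenyl gives a 1.2-fold lower number from compound 2 to compound 4 (0.08 log units; within the scatter), and this is the first reading of a single change on this ring, since the earlier steps offered none there. Fluoro at this place, para to a large group, therefore leaves the number within the scatter of the parent, as the change on the other aryl ring does in the step of a 1.2-fold lower number from compound 2 to compound 3 (0.06 log units; within the scatter), so neither of the two single changes read so far separates a pair of compounds in this series. No measurement at hand offers a reason for this reading or says what the fluoro does at this place.

With all four compounds within the scatter of their neighbours, the series does not yet show whether any change on this ring can move the number at all, and an amine, a carboxylic acid or a longer chain such as butyl at the same place remains an open test. As far as these compounds go, whether fluoro on this ring would read the same way on another cell line, or at another exposure time, also stays open.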